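Swapping 4-Fluorobenzyl for 2-Methoxyphenoxy: Expected Permeability

This account rests on a few compounds, and the source may have more. Where it says the series, first, only, none or still open, it means among the compounds named here.

Measured compounds:
Compound 1, `CCC(CC)c1ccc2c(NCCCNCc3cc(F)ccc3OC)ccnc2c1`, in an ADME assay for permeability, using PAMPA, with a stated time of 30 min, at pH 7.4 (on this read-out lower numbers stand for lower permeability and higher numbers for higher permeability), compound 1 gives 23 10^-6 cm/s.
Compound 2, `COc1ccc(F)cc1CNCCCNc1ccnc2cc(Cc3ccc(F)cc3)ccc12`, in this assay compound 2 gives 23 10^-6 cm/s.

On the numbers shown, compound 2 stands level with compound 1 in this assay: the step of no change at the digits printed from compound 1 to compound 2 (within the scatter), in which 4-fluorobenzyl replaced pentan-3-yl on an aromatic carbon, left the read-out where it was. Among the compounds with values here, that is the only measured step available, and it shows that at this position on the shared core an exchange of one substituent for another has so far not moved permeability beyond the scatter.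

Compound 3, `COc1ccc(F)cc1CNCCCNc1ccnc2cc(Oc3ccccc3OC)ccc12`, is not yet measured. It differs from compound 2 as follows: 2-methoxyphenoxy in place of 4-fluorobenzyl on an aromatic carbon. The entering group brings two hydrogen-bond acceptors where the leaving group had none, which the measured step does not cover, so the expectation rests mainly on the unchanged result from compound 1 to compound 2. For compound 3 the step of a 1.2-fold lower number from compound 2 to compound 3 (0.06 log units; within the scatter) is expected to stay within the scatter. Compound 3 is therefore estimated at 20 10^-6 cm/s in this assay, with a range of 10 10^-6 cm/s to 35 10^-6 cm/s.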

Compound 3, apparent permeability: 317 10^-6 cm/s
Compound 3: middle estimate off by 16-fold (1.20 log units), on the low side; the measured number lies above the stated range.
By their numbers in this assay, from the lowest: compounds 1 and 2 (each within the scatter of the next); then compound 3.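

In this assay, the position on the shared core turned out not to be indifferent: 2-methoxyphenoxy in place of 4-fluorobenzyl gave a 14-fold higher number from compound 2 to compound 3 (1.14 log units; beyond the scatter), and 2-methoxyphenoxy in place of pentan-3-yl gave a 14-fold higher number from compound 1 to compound 3 (1.14 log units; beyond the scatter). Within the data shown here, the exchange of pentan-3-yl for 4-fluorobenzyl had left the read-out unchanged, so that earlier step showed only that these two groups are alike here, not that the position tolerates any exchange without effect on the number; of the two changes from compound 2, the counted difference is that 2-methoxyphenoxy has 2 hydrogen-bond acceptors where 4-fluorobenzyl has 0. No measurement shown here explains why the number rose so far with this group.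

The compounds shown do not separate the parts of the entering group, so it remains open whether the ring oxygen link or the methoxy carries the step. A plain phenoxy or a 2-methoxybenzyl group at this position would divide the two, and an amine there would show whether the rise extends beyond oxygen-bearing groups.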